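Thiourea aryl swap: from methylphenyl to chlorophenyl

This account rests on a few compounds, and the source may have more. Where it says the series, first, only, none or still open, it means among the compounds named here.

Within the data shown here, compound 2 `COc1cc2c(cc1OC)C(=O)C(CC1CCN(C(=S)Nc3ccc(C)cc3)CC1)C2` gives 30 mg/kg in a functional assay on the whole organism (strain Swiss albino) with Mus musculus as the target, in the maximal electroshock model, with a stated time of 0.5 h (a lower number here means that less compound is needed, a higher number that more compound is needed for the effect), the lowest of the two numbers known so far; its neighbour compound 1 `COc1cc2c(cc1OC)C(=O)C(CC1CCN(C(=S)Nc3ccccc3)CC1)C2` gives 100 mg/kg. Compound 3 `COc1cc2c(cc1OC)C(=O)C(CC1CCN(C(=S)Nc3cccc(Cl)c3)CC1)C2` is not yet measured. It differs from compound 2 in one place: 3-chlorophenyl in place of 4-methylphenyl on an amide-type nitrogen. Among the measured compounds shown here, the only measured step, a 3.3-fold lower number from compound 1 to compound 2 (0.52 log units; beyond the scatter), concerns methyl in place of hydrogen on an aromatic carbon and so does not directly bear on exchanging 4-methylphenyl for 3-chlorophenyl; no measured pair shows what chlorine at that position does. With nothing pointing either way, no step beyond the scatter is expected, and compound 3 is estimated at 30 mg/kg, within the range 10 mg/kg to 100 mg/kg, which corresponds to an expected step of no change at the digits printed from compound 2 to compound 3 (within the scatter). This estimate rests on compound 2 alone, because its value 30 mg/kg is the nearest measured point.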

Compound 3, minimum effective dose: 300 mg/kg
Beside the measured number, compound 3's estimate is 10-fold (1.00 log units) below it; measured number above the stated range.
By their numbers in this assay, from the lowest: compound 2; then compound 1; then compound 3.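

The aryl group on the thiourea nitrogen clearly matters in this assay: 3-chlorophenyl in place of 4-methylphenyl gives a 10-fold higher number from compound 2 to compound 3 (1.00 log units; beyond the scatter). Measured against the unsubstituted phenyl, chloro in place of hydrogen gives a 3.0-fold higher number from compound 1 to compound 3 (0.48 log units; beyond the scatter), whereas methyl in place of hydrogen gave a 3.3-fold lower number from compound 1 to compound 2 (0.52 log units; beyond the scatter), so among these compounds a substituent on this ring can move the required dose in either direction. No measurement at hand explains this difference.

The compounds shown do not separate the effect of chlorine from the effect of its place on the ring, as chloro and methyl never occupy the same position here. On these data alone, it also remains open whether a methoxy group or an amine on this ring would behave more like the methyl or the chloro group.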